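The compounds below may be only part of what the source reports. "The series", "measured", "known", "first", "only" and "open" are said of these compounds alone.

Measured compounds:
Compound 1 `COc1ncnc2c1c(-c1ccsc1)cn2[C@@H]1O[C@H](CO)[C@@H](O)[C@H]1O` gives 75300 nM in an ADME assay on MRC5 cells (Homo sapiens), read by MTT assay, with a stated time of 72 h; a higher number here means a weaker inhibitor, a lower number a stronger inhibitor.
Compound 2 `COc1nc(N)nc2c1c(-c1ccsc1)cn2[C@@H]1O[C@H](CO)[C@@H](O)[C@H]1O` reaches only the limit > 100000 nM in this assay, which is not a number.
Compound 3 `O=c1[nH]cnc2c1c(-c1ccco1)cn2[C@@H]1O[C@H](CO)[C@@H](O)[C@H]1O` likewise reaches only the limit > 100000 nM in this assay.

Compound 1 and compound 2 differ in one place: amino in place of hydrogen on an aromatic carbon. The step is an at least 1.3-fold higher number from compound 1 to compound 2 (0.12 log units; that floor lies within the scatter). The cores of compound 1 and compound 3 differ in more than one place, and that difference is not broken down here.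

Compound 4 `Nc1nc2c(c(-c3ccco3)cn2[C@@H]2O[C@H](CO)[C@@H](O)[C@H]2O)c(=O)[nH]1` is not yet measured. It differs from compound 3 by amino in place of hydrogen on an aromatic carbon, the same kind of change as from compound 1 to compound 2, though the surroundings are not identical: in compound 1 the carbon sits meta to a methoxy group (2 heavy atoms), in compound 3 meta to a group of 1 heavy atom.

Because of the limit of > 100000 nM in this assay, at which 2 of the 3 values shown sit, and because compound 3 itself sits at that limit with > 100000 nM, compound 4 is expected to stay at or past it, with an expected step that the limit leaves unreadable from compound 3 to compound 4. The estimate for compound 4 in this assay is 150000 nM, expected to lie from 60000 nM to 400000 nM.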

Compound 4, half-maximal inhibitory concentration: > 100000 nM
Compound 4 ended at the assay's limit; the forecaster's own chance of this, stated with the estimate: 85%; the middle value does not contradict the limit.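

Compound 3 and compound 4 both end at a limit of this assay rather than at a number, so no step can be read between them: the limit of > 100000 nM in this assay, at which 3 of the 4 values shown sit.

The compounds shown leave open how far past that limit compound 3 and compound 4 lie, and whether amino in place of hydrogen changes anything in this pair.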